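Lengthening the chain again: from iodo to hexyloxy

The compounds below may be only part of what the source reports. "The series", "measured", "known", "first", "only" and "open" are said of these compounds alone.

Of the compounds shown here, three sharing one core have been measured in a functional assay on M21 cells (Homo sapiens) for antiproliferative activity, read by sulforhodamine B assay, with a stated time of 48 h; on this read-out higher numbers stand for weaker inhibition and lower numbers for stronger inhibition. Compound 1 `CCCCCc1ccc(NS(=O)(=O)c2ccc(N3CCNC3=O)cc2)cc1` gives 870 nM, compound 2 `CCc1ccc(NS(=O)(=O)c2ccc(N3CCNC3=O)cc2)cc1` gives 480 nM, and compound 3 `O=C1NCCN1c1ccc(S(=O)(=O)Nc2ccc(I)cc2)cc1` gives 260 nM. Among these three numbers compound 3 has the lowest; its step to compound 2 is within the scatter, while the step from compound 1 to compound 3 a 3.3-fold lower number from compound 1 to compound 3 (0.52 log units; beyond the scatter) is beyond it. Compound 4 `CCCCCCOc1ccc(NS(=O)(=O)c2ccc(N3CCNC3=O)cc2)cc1` is the next to be measured. Its difference from compound 3 is hexyloxy in place of iodo on an aromatic carbon. For the measured compounds named here, two measured steps bear on this. Replacing a long chain by iodo, a 3.3-fold lower number from compound 1 to compound 3 (0.52 log units; beyond the scatter), gave the largest change seen so far, and replacing a short chain by iodo, a 1.8-fold lower number from compound 2 to compound 3 (0.27 log units; within the scatter), a smaller one. Going the other way, from iodo to a long chain, the number is therefore expected to rise, in the direction of compound 1, probably beyond the scatter. Compound 4 is estimated at 900 nM, with a range from 300 nM to 3000 nM, which corresponds to an expected step of a 3.5-fold higher number from compound 3 to compound 4 (0.54 log units; beyond the scatter).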

Compound 4, half-maximal inhibitory concentration: > 1000 nM
Compound 4: a limit, no number (the forecaster's own chance of this, stated with the estimate: 3%); middle value at least 1.1-fold (0.04 log units) away from the limit.
By their numbers in this assay, from the lowest: compounds 3, 2 and 1 (each within the scatter of the next, the first and the last beyond it). At a limit, above all of these: compound 4.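

Compound 4 sits at a limit of the assay, > 1000 nM, and not at a number, so its steps are floors. Even as floors, they show that this position does not tolerate every group equally: hexyloxy, with 7 heavy atoms in place of the single iodine, gives an at least 3.8-fold higher number from compound 3 to compound 4 (0.58 log units; beyond the scatter), and against ethyl it gives an at least 2.0-fold higher number from compound 2 to compound 4 (0.31 log units; beyond the scatter), a separation beyond the scatter that pentyl in compound 1 did not reach against ethyl. Against pentyl itself the floor is an at least 1.1-fold higher number from compound 1 to compound 4 (0.06 log units; that floor lies within the scatter), so these two long chains cannot be put in order.

As far as these compounds go, how far compound 4 really lies past the limit stays unknown, because the assay gives no number there: the limit of > 1000 nM in this assay, at which 1 of the 4 values shown sits. Also open is how a shorter chain joined through oxygen, such as methoxy, or an amine on this aromatic carbon would compare with iodo.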